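The source may hold more compounds than are shown below. What is called first, only, known or untested is meant among the compounds shown, and "the series" means these compounds.

In an ADME assay on Caco-2 cells (Homo sapiens) for permeability, in the apical to basolateral direction (on this read-out higher numbers stand for higher permeability and lower numbers for lower permeability), the measured compounds so far are:

compound 1, `C=C(C)C(=O)N1CCC(CN(C2Cc3cc(C#N)ccc3N(Cc3cncn3C)C2)S(=O)(=O)c2ccccn2)CC1`, giving 0.5 10^-6 cm/s
compound 2, `Cn1cncc1CN1CC(N(CC2CCN(C(=O)N3CCCCC3)CC2)S(=O)(=O)c2ccccn2)Cc2cc(C#N)ccc21`, giving 0.6 10^-6 cm/s

Among the compounds with values here, compound 2 holds the higher of the two numbers, but the only comparison available, a 1.2-fold higher number from compound 1 to compound 2 (0.08 log units; within the scatter), is within the scatter, so compound 2 and compound 1 sit at the same level on this read-out.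

Compound 3, `Cn1cncc1CN1CC(N(CC2CCN(C(=O)CC(F)(F)F)CC2)S(=O)(=O)c2ccccn2)Cc2cc(C#N)ccc21`, is not yet measured. It differs from compound 2 by 2,2,2-trifluoroethyl in place of piperidin-1-yl on a carbonyl carbon.

Within the data shown here, the one measured step that bears on this change is the earlier exchange at the same carbonyl carbon, a 1.2-fold higher number from compound 1 to compound 2 (0.08 log units; within the scatter), which stayed within the scatter. Nothing in the measured pair points to a shift in this assay, so no step beyond the scatter is expected from compound 2 to compound 3: no change at the digits printed from compound 2 to compound 3 (within the scatter).

Compound 3 is therefore estimated at 0.6 10^-6 cm/s in this assay. For compound 3 the expected range runs from 0.3 10^-6 cm/s to 1.3 10^-6 cm/s.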

Compound 3, apparent permeability: 0.5 10^-6 cm/s
Compound 3: middle estimate off by 1.2-fold (0.08 log units), on the high side; measured number inside the range.
By their numbers in this assay, from the lowest: compounds 1, 3 and 2 (each within the scatter of the next).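

At this carbonyl carbon in this assay, 2,2,2-trifluoroethyl in place of piperidin-1-yl gives a 1.2-fold lower number from compound 2 to compound 3 (0.08 log units; within the scatter), and 2,2,2-trifluoroethyl in place of 1-methylethenyl gives no change at the digits printed from compound 1 to compound 3 (within the scatter), so all three groups read at one level. The earlier pair held no fluorine-bearing group; the series now shows that a fluorinated chain with no ring also produces no step beyond the scatter at this position. No measurement available here accounts for this flat reading.

From the compounds shown here alone, whether a chain ending in an amine or a carboxylic acid at this carbonyl carbon would produce a step beyond the scatter remains open. Going by these compounds, all three compounds also share the rest of their structure, so it is open whether this level holds when the shared core changes.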